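The source may report more compounds than this note shows. Statements on the series, on what has been measured and on what is new or still open speak of the compounds shown alone.

Working notes on the series in an assay on HEK293 cells for positive allosteric modulation of metabotropic glutamate receptor 2 (Rattus norvegicus), read by thallium flux, with a stated time of 2.5 min; a lower number here means a smaller maximal response, a higher number a larger maximal response.

Three members have been measured. Compound 1 `Cc1c(OCCCCOc2ccc(C(=O)O)cc2F)ccc(C(=O)CC(C)C)c1O` gives 85% in this assay. Compound 2 `COC(=O)c1ccc(OCCCCOc2ccc(C(=O)CC(C)C)c(O)c2C)cc1` gives 16.4%. Compound 3 `Cc1ccc(C(=O)O)cc1OCCCCOc1ccc(C(=O)CC(C)C)c(O)c1C` gives 76.9%. Compound 3 thus stands second highest of the three numbers; its nearest neighbour is compound 1, with a number 8.1 percentage points lower from compound 1 to compound 3 (within the scatter), and its furthest is compound 2, with a number 60.5 percentage points higher from compound 2 to compound 3 (beyond the scatter).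

Compound 4 `Cc1cc(OCCCCOc2ccc(C(=O)CC(C)C)c(O)c2C)ccc1C(=O)O` is the next member and has not yet been measured. It differs from compound 3 as follows: 4-carboxy-3-methylphenyl in place of 5-carboxy-2-methylphenyl on an oxygen on a saturated carbon.

Among the compounds with values here, two measured steps bear on this change. The step with a number 68.6 percentage points lower from compound 1 to compound 2 (beyond the scatter) and the step with a number 60.5 percentage points higher from compound 2 to compound 3 (beyond the scatter) both involve the 4-(methoxycarbonyl)phenyl compound and are large, but compound 4 keeps a carboxy group, so they say little about its case. The step with a number 8.1 percentage points lower from compound 1 to compound 3 (within the scatter), which also exchanges one carboxy-bearing phenyl for another, lies within the scatter. The change from compound 3 to compound 4 is of that kind, so the expected step in this assay is none beyond the scatter, with the estimate a number 0.9 percentage points lower from compound 3 to compound 4 (within the scatter).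

Compound 4 is therefore expected to give about 76% in this assay, with a range from 55% to 92%.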

Compound 4, largest response reached (reported as percent of maximum), in percent of the reference or control that the assay uses: 93.3%
Compound 4: the middle estimate sits 17.3 percentage points below what was measured; the measured number lies above the stated range.
By their numbers in this assay, from the lowest: compound 2; then compounds 3, 1 and 4 (each within the scatter of the next, the first and the last beyond it).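

In this assay, placing 4-carboxy-3-methylphenyl in place of 5-carboxy-2-methylphenyl on the oxygen gives a number 16.4 percentage points higher from compound 3 to compound 4 (beyond the scatter) and so shows that exchanges among carboxy-bearing phenyl groups at this position are not uniformly silent, although the two groups have the same atoms and the same counted features. The arrangement of the same atoms within the group therefore matters in this pair, a point that the earlier comparison of compound 1 and compound 3 could not reveal. The new group still cannot be separated from 4-carboxy-2-fluorophenyl, with a number 8.3 percentage points higher from compound 1 to compound 4 (within the scatter) as the printed step, while the 4-(methoxycarbonyl)phenyl compound remains far apart, with a number 76.9 percentage points higher from compound 2 to compound 4 (beyond the scatter) as the step to the new member.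

No measurement at hand accounts for the difference between the two carboxy-methyl arrangements.

Still open, as far as these compounds go, is whether a tetrazole or a primary amide could stand in place of the carboxylic acid on this ring and hold the maximal response, and whether a longer chain between the two oxygens would keep the gap between compound 3 and compound 4.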